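The source may report more compounds than this note shows. Statements on the series, on what has been measured and on what is new or still open speak of the compounds shown alone.

Measured compounds in a functional assay on NIH3T3 cells (Mus musculus) for inhibition, read by MTT assay, with a stated time of 72 h; on this read-out higher numbers stand for weaker inhibition and lower numbers for stronger inhibition:
compound 1 `C=C1CC[C@H]2[C@@](C)(CC[C@@H](OC(C)=O)[C@@]2(C)C(=O)OC)[C@@H]1CCC1=CCOC1=O` gives 80600 nM
compound 2 `C=C1CC[C@H]2[C@@](C)(CC[C@@H](OC(C)=O)[C@@]2(C)C(=O)OCc2ccccc2)[C@@H]1CCC1=CCOC1=O` gives 12900 nM
compound 3 `C=C1CC[C@H]2[C@@](C)(CC[C@@H](O)[C@@]2(C)C(=O)OC)[C@@H]1C/C=C1\C=COC1=O` gives 177000 nM

Compound 2 is derived from compound 1 by a single change: phenyl in place of hydrogen on a saturated chain carbon bound to an oxygen next to a carbonyl group This change produced a 6.2-fold lower number from compound 1 to compound 2 (0.80 log units; beyond the scatter). Compound 3 carries a different core; the difference between the two cores is not broken down here. Of the three numbers compound 3 has the highest, with compound 1 nearest and compound 2 furthest.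

Compound 4 `C=C1CC[C@H]2[C@@](C)(CC[C@@H](O)[C@@]2(C)C(=O)OCc2ccccc2)[C@@H]1C/C=C1\C=COC1=O` has not been measured. It is made from compound 3 by the same kind of change: phenyl in place of hydrogen on a saturated chain carbon bound to an oxygen next to a carbonyl group The place of the change is described in the same words for both pairs. Because the earlier step of a 6.2-fold lower number from compound 1 to compound 2 (0.80 log units; beyond the scatter) lay beyond the scatter, a step of comparable size is expected in this assay: a 5.9-fold lower number from compound 3 to compound 4 (0.77 log units; beyond the scatter). The expectation rests on one measured pair only and is held loosely. Compound 4 is therefore estimated at 30000 nM, with a range from 12000 nM to 80000 nM.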

Compound 4, half-maximal inhibitory concentration: 177000 nM
Beside the measured number, compound 4's estimate is 5.9-fold (0.77 log units) below it; measured number above the stated range.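

In this assay the exchange of methoxycarbonyl for benzyloxycarbonyl gives no change at the digits printed from compound 3 to compound 4 (within the scatter), so the drop in the number seen on the core of compound 1 does not reappear on the core of compound 3: the same change on two cores in this assay, a 6.2-fold lower number (0.80 log units; beyond the scatter) from compound 1 to compound 2 and no change at the digits printed (within the scatter) from compound 3 to compound 4, 6.2-fold (0.80 log units) apart, beyond the scatter of two such steps. This shows that, across these two pairs, the size of the step does not transfer from one core to the other, and a step measured on one core is a poor guide to the other. It does not show which feature of the two cores separates the outcomes, since they are compared as wholes, and with one pair per core it gives no general rule for either core.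

Still open, from the compounds shown here alone, is whether a carboxylic acid, an amide or a longer chain such as phenethyl, in place of the benzyloxycarbonyl group, would separate the two cores in the same way. Also open, going by these compounds, is whether a chloro or methoxy substituent on the phenyl ring would change the number on either core.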